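The compounds below may be only part of what the source reports. "The series", "measured", "known", "first", "only" and "open" are said of these compounds alone.

Compound 1, `CC1CCN(C2CCN(S(=O)(=O)c3ccc(Br)cc3OC(F)(F)F)CC2)CC1`: in a functional assay on DLD-1 cells (Homo sapiens) for antiproliferative activity, read by CellTiter-Glo, with a stated time of 72 h (a higher number here means a weaker inhibitor, a lower number a stronger inhibitor), compound 1 gives 5 nM.
Compound 2, `Cc1ccc(C2CCN(S(=O)(=O)c3c(C)cc(C)cc3C)CC2)cc1`: in this assay compound 2 gives 2200 nM.
Compound 3, `COc1cccc(S(=O)(=O)N2CCC(N3CCC(C)CC3)CC2)c1`: in this assay compound 3 reaches only a limit, > 5000 nM; this is the limit of > 5000 nM in this assay, at which 1 of the 3 values shown sits.

Among the two numbers that were actually read, compound 2 stands highest; its nearest neighbour is compound 1, whose number is far lower, a gap well beyond the scatter. The third compound, compound 3, contributes a limit rather than a number.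

Compound 4, `Cc1cc(C)c(S(=O)(=O)N2CCC(N3CC(C)CC(C)C3)CC2)c(C)c1`, is not yet measured. It differs from compound 2 in one place: 3,5-dimethylpiperidin-1-yl in place of 4-methylphenyl on a saturated ring carbon. Compound 1 and compound 3 both carry a saturated amine ring at that same position and differ only in the sulfonyl aryl group, yet their readings lie at opposite ends of the range; the aryl group of compound 4 matches that of compound 2, not that of compound 1. Within the data shown here, no measured pair isolates the change at hand, so the direction is uncertain. The estimate for compound 4 in this assay is 500 nM, within 50 nM to 5000 nM, which corresponds to an expected step of a 4.4-fold lower number from compound 2 to compound 4 (0.64 log units; beyond the scatter) toward a stronger inhibitor.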

Compound 4, half-maximal inhibitory concentration: 17 nM
The estimate for compound 4 lay 29-fold (1.47 log units) above the measured number, and the stated range ends above it.
By their numbers in this assay, from the lowest: compound 1; then compound 4; then compound 2. At a limit, above all of these: compound 3.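

At this saturated ring carbon, 3,5-dimethylpiperidin-1-yl in place of 4-methylphenyl gives a 130-fold lower number from compound 2 to compound 4 (2.11 log units; beyond the scatter) in this assay, and this is the only pair shown in which nothing but this position changes. Among these compounds, with the sulfonyl aryl group held fixed, the group on this carbon alone therefore moves the number by a large step, which the earlier compounds could not show. Compound 1 and compound 3 both carry a saturated amine ring here and speak only to the aryl group, whereas compound 4 shows that a saturated amine ring at this position also goes with a low number when the aryl group is that of compound 2.

The values shown give no reason for the size of this step. The change replaces an aromatic carbon ring with a non-aromatic ring holding a nitrogen and also alters the methyl groups, so these features stay unseparated, and a plain piperidine, a morpholine or a cyclohexyl group on this carbon would bear on which of them matters.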